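A Trifluoromethyl Group Relocated on a Pendant Phenyl Ring

The source may report more compounds than this note shows. Statements on the series, on what has been measured and on what is new or still open speak of the compounds shown alone.

Among the measured compounds shown here, compound 2 `Oc1ccccc1-c1cc(-c2ccccc2C(F)(F)F)cc(-c2ccccc2O)n1` is the only compound with a numerical result in this set. In a functional assay on HCT-15 cells (Homo sapiens) for inhibition (a higher number here means a weaker inhibitor, a lower number a stronger inhibitor), compound 2 gives 3970 nM. Compound 1 `Oc1ccccc1-c1cc(-c2ccc(F)cc2)cc(-c2ccccc2O)n1` gives only a limit of the assay in this assay, > 50000 nM. For the measured compounds named here, the single measured step, an at least 12-fold lower number from compound 1 to compound 2 (1.10 log units; beyond the scatter), rests on the limit of > 50000 nM in this assay, at which 1 of the 2 values shown sits, and shows that the pendant aryl group on the shared core can move the result a long way. Compound 3 `Oc1ccccc1-c1cc(-c2cccc(C(F)(F)F)c2)cc(-c2ccccc2O)n1` is next to be measured. It differs from compound 2 by 3-(trifluoromethyl)phenyl in place of 2-(trifluoromethyl)phenyl on an aromatic carbon: the same atoms, joined differently, with the trifluoromethyl group shifted to another position on the pendant phenyl ring. Going by the values given here, no measured step compares two positions of the same group, so the measured step of an at least 12-fold lower number from compound 1 to compound 2 (1.10 log units; beyond the scatter) gives only a sense of how far a change on this ring may carry, not its direction here. Compound 3 is therefore expected to show a step of a 1.3-fold higher number from compound 2 to compound 3 (0.10 log units; within the scatter), one that could stay within the scatter or slightly exceed it in either direction. The estimate for compound 3 in this assay is 5000 nM, within the range 1500 nM to 20000 nM.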

Compound 3, half-maximal inhibitory concentration: > 50000 nM
Compound 3 was reported as a limit; the forecaster's own chance of this, stated with the estimate: 15%; middle value at least 10-fold (1.00 log units) away from the limit.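

The position of the trifluoromethyl group on the pendant phenyl ring matters in this assay: with the same atoms joined differently, 3-(trifluoromethyl)phenyl in place of 2-(trifluoromethyl)phenyl gives an at least 12-fold higher number from compound 2 to compound 3 (1.10 log units; beyond the scatter). The earlier step changed both the substituent and its position, whereas this one changes the position alone, so a trifluoromethyl group on this ring does not by itself give a measurable result, and of the two isomers only compound 2 has a number. Compound 3 and compound 1 are each reported only as a limit of the assay, so the step between them cannot be read, and the set now rests largely on that limit: the limit of > 50000 nM in this assay, at which 2 of the 3 values shown sit.

The compounds shown leave open how a 4-(trifluoromethyl)phenyl group would stand on the same carbon, which would complete the series of positions for this substituent. They also leave open whether the number of compound 2 is particular to trifluoromethyl or would also appear with a different group at the same ring position, such as the chlorine of 2-chlorophenyl or the methyl of 2-methylphenyl.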